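Trifluoromethyl on the aryl ring of dienone cytotoxins

The source may hold more compounds than are shown below. What is called first, only, known or untested is meant among the compounds shown, and "the series" means these compounds.

Measured in a functional assay on LNCaP cells (Homo sapiens) for cytotoxicity, read by MTT assay, with a stated time of 72 h; a lower number here means a stronger inhibitor, a higher number a weaker inhibitor:
compound 1, `CC1=CCCC(C)(C)C1/C=C/C(=O)/C=C/c1ccccc1F`, gives 1600 nM
compound 2, `CC1=CCCC(C)(C)C1/C=C/C(=O)/C=C/c1cc(C(F)(F)F)ccc1F`, gives 1700 nM
compound 3, `CC1=C(/C=C/C(=O)/C=C/c2cccc(C(F)(F)F)c2)C(C)(C)CCC1O`, gives 740 nM

Compound 1 and compound 2 share one core; the change between them is trifluoromethyl in place of hydrogen on an aromatic carbon and it made a 1.1-fold higher number from compound 1 to compound 2 (0.03 log units; within the scatter). Compound 3 carries a different core; the difference between the two cores is not broken down here. Its number in this assay is the lowest of the three, and its steps to compound 1 and to compound 2 are both beyond the scatter.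

Compound 4, `CC1=C(/C=C/C(=O)/C=C/c2cc(C(F)(F)F)ccc2C(F)(F)F)C(C)(C)CCC1O`, is not yet measured. It differs from compound 3 by trifluoromethyl in place of hydrogen on an aromatic carbon. Within the data shown here, this is the same kind of change as the one from compound 1 to compound 2, but not the same: here the entering group stands ortho to a large group and para to a trifluoromethyl group, whereas in compound 2 it stands meta to a large group and para to a fluoro group.

The step from compound 3 to compound 4 in this assay is expected to be a 1.1-fold higher number from compound 3 to compound 4 (0.06 log units; within the scatter), set beside a 1.1-fold higher number from compound 1 to compound 2 (0.03 log units; within the scatter) because that earlier step, a 1.1-fold higher number from compound 1 to compound 2 (0.03 log units; within the scatter), lay within the scatter. Compound 4 is thus estimated at 850 nM, with a likely range from 400 nM to 1800 nM.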

Compound 4, half-maximal inhibitory concentration: 3200 nM
Estimate against measurement, compound 4: 3.8-fold (0.58 log units) below; the measured number lies above the stated range.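

In this assay the new step is a 4.3-fold higher number from compound 3 to compound 4 (0.64 log units; beyond the scatter) and so trifluoromethyl in place of hydrogen on an aromatic carbon does not carry over at one size from core to core in this series. The step seen on the first core gives no safe reading of the step on the second, as the two differ by more than the scatter: the same change on two cores in this assay, a 1.1-fold higher number (0.03 log units; within the scatter) from compound 1 to compound 2 and a 4.3-fold higher number (0.64 log units; beyond the scatter) from compound 3 to compound 4, 4.1-fold (0.61 log units) apart, beyond the scatter of two such steps. Among these compounds, this does not show whether the core or the place on the ring sets the difference, as the entering group in compound 4 stands ortho to a large group and para to a trifluoromethyl group, a place not shared with compound 2, and each core offers only one such pair.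

Open, going by these compounds, is whether another group at the same place in compound 4, such as a methoxy group or a nitrile, would give a step of similar size. Also open, on these data alone, is what trifluoromethyl does at that same place on the core of compound 1.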